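Trimming a Methyl from an Inactive Hydantoin

This account rests on a few compounds, and the source may have more. Where it says the series, first, only, none or still open, it means among the compounds named here.

Measured so far:
- compound 1 `CCC(C)C1NC(=O)N(C2CCCCC2)C1=O`: > 200000 nM
- compound 2 `CCC(C)C(NC(=O)NO)C(=O)NC1CCCCC1`: 89000 nM

Of the compounds shown here, two have been tested in a functional assay on L1210 cells (Mus musculus) for inhibition; a higher number here means a weaker inhibitor, a lower number a stronger inhibitor. Compound 1 gives no number in this assay, only a limit, (the limit of > 200000 nM in this assay, at which 1 of the 2 values shown sits). Compound 2, built on a different, open-chain skeleton, gives a measured value in this assay, 89000 nM. Compound 1 and compound 2 do not share a skeleton. Among the compounds with values here, their pair tells nothing about a single structural change, and no step between measured compounds is available.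

Compound 3 `CC(C)C1NC(=O)N(C2CCCCC2)C1=O` has not yet been measured. It differs from compound 1 by one change: hydrogen in place of methyl on a saturated chain carbon, two bonds along the chain from a saturated ring carbon. Within the data shown here, since compound 1 shows only a limit, the starting point for this step is itself uncertain; there is no measured value from which a shift could be read, and no step anywhere in the data describes what losing a methyl from this chain does.

The expected step is a step that the limit leaves unreadable from compound 1 to compound 3, that is, no change beyond the scatter. Compound 3 is expected to come out near 300000 nM, within a range from 100000 nM to 1000000 nM, and most likely as another limit rather than a number.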

Compound 3, half-maximal inhibitory concentration: > 200000 nM
Compound 3: no number, only a limit; the forecaster's own chance of this, stated with the estimate: 75%; the middle value lies beyond the limit too.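

Compound 1 and compound 3 each give only a limit in this assay, not a number, so no step between them can be read for the change from sec-butyl to isopropyl: the limit of > 200000 nM in this assay, at which 2 of the 3 values shown sit.

The compounds shown leave open whether this chain affects inhibition at all on the core of compound 1.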